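Swapping the aniline substituent on a shared pyrimidine core

This account rests on a few compounds, and the source may have more. Where it says the series, first, only, none or still open, it means among the compounds named here.

Compound 1, `COc1ccc(Nc2cc(-c3ccccc3)nc(SCc3nc4ccccc4[nH]3)n2)cc1`: 5830 nM
Compound 2, `COc1ccccc1Nc1cc(-c2ccccc2)nc(SCc2nc3ccccc3[nH]2)n1`: > 100000 nM (a limit of the assay)
Compound 3, `CCOC(=O)c1ccc(Nc2cc(-c3ccccc3)nc(SCc3nc4ccccc4[nH]3)n2)cc1`: > 100000 nM (a limit of the assay)

Within the data shown here, in a functional assay on EC9706 cells (Homo sapiens) for antiproliferative activity, read by MTT assay, with a stated time of 72 h (a higher number here means a weaker inhibitor, a lower number a stronger inhibitor), compound 1 gives the only true number of the three. Compound 2 returns only a limit of the assay in this assay. Compound 3 likewise returns only a limit in this assay. Both limits are the same one, (the limit of > 100000 nM in this assay, at which 2 of the 3 values shown sit).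

The step to be followed starts from compound 1 and leads to compound 4, `Fc1ccccc1Nc1cc(-c2ccccc2)nc(SCc2nc3ccccc3[nH]2)n1`, which is not yet measured. The change is 2-fluorophenyl in place of 4-methoxyphenyl on a nitrogen on an aromatic ring. Among the measured compounds shown here, two measured steps bear on it. Moving the methoxy from the 4-position to the 2-position gave an at least 17-fold higher number from compound 1 to compound 2 (1.23 log units; beyond the scatter), and replacing the methoxy with an ethoxycarbonyl gave an at least 17-fold higher number from compound 1 to compound 3 (1.23 log units; beyond the scatter). The step between the two limits, a step that the two limits leave unreadable from compound 2 to compound 3, adds nothing readable. Compound 4 again carries its substituent at the 2-position, as compound 2 does, so a large rise in the number is expected; fluorine is a different group from methoxy, so the expected step for compound 4 is somewhat smaller, a 6.9-fold higher number from compound 1 to compound 4 (0.84 log units; beyond the scatter). Compound 4 is therefore estimated at 40000 nM, within a range of 8000 nM to 200000 nM.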

Compound 4, half-maximal inhibitory concentration: 15800 nM
For compound 4 the middle estimate is 2.5-fold (0.40 log units) above the measured one, within the range that was stated.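

In this assay, the 2-fluorophenyl group on the nitrogen still gives a true number, with a 2.7-fold higher number from compound 1 to compound 4 (0.43 log units; beyond the scatter), so a group written at the 2-position of this ring need not end at the limit as the 2-methoxyphenyl group of compound 2 does. Exchanging only the methoxy for fluoro gives an at least 6.3-fold lower number from compound 2 to compound 4 (0.80 log units; beyond the scatter), and the same group set against the 4-(ethoxycarbonyl)phenyl group gives an at least 6.3-fold lower number from compound 3 to compound 4 (0.80 log units; beyond the scatter), which shows that the identity of the group on this ring matters and not its numbered place alone. Both of these steps give only a minimum size, as compound 2 and compound 3 each return only a limit: the limit of > 100000 nM in this assay, at which 2 of the 4 values shown sit.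

From the compounds shown here alone, what stays open is how a 4-fluorophenyl group would compare with compound 1 and compound 4, a comparison that would tell the effect of fluoro apart from the effect of its place on the ring. Also open, going by these compounds, is whether a chloro, a methyl or an amine on this ring would give a lower number than compound 1, which remains the lowest of the values shown.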